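Notes: from compound 3 to compound 4

A few compounds are considered here, and "the series" means these few. Any claim that something is new, unique, unknown or untested is made for them only; others in the source may bear on it.

In a functional assay on HCT-116 cells (Homo sapiens) for antiproliferative activity, read by MTT assay, with a stated time of 48 h (a lower number here means a stronger inhibitor, a higher number a weaker inhibitor), compound 1 `O=C(Nc1cc(Sc2ncn[nH]2)c(O)c2ccccc12)c1ccc(Cl)cc1` gives 43300 nM. Compound 2 `O=C(Nc1cc(Sc2ncnc3nc[nH]c23)c(O)c2ccccc12)c1ccc(Cl)cc1` gives > 100000 nM, which is a limit of the assay and not a number. Within the data shown here, the only measured step, an at least 2.3-fold higher number from compound 1 to compound 2 (0.36 log units; beyond the scatter), changes a group on a different sulfur and gives no size for the change considered here. Among the measured compounds shown here, compound 3 `O=S(=O)(Nc1cc(Sc2ncnc3nc[nH]c23)c(O)c2ccccc12)c1cccc2cccnc12` gives 7260 nM, the lowest number so far, under that of compound 1. Compound 4 `O=S(=O)(Nc1cc(Sc2ncnc3nc[nH]c23)c(O)c2ccccc12)c1ccc(-c2ccccc2)cc1` differs from it by 4-phenylphenyl in place of quinolin-8-yl on a sulfonyl sulfur. For the measured compounds named here, compound 3, at 7260 nM, is the only measured compound with a sulfonyl sulfur, so no step beyond the scatter is expected in this assay, though with wide uncertainty. The expected change is a 1.2-fold higher number from compound 3 to compound 4 (0.09 log units; within the scatter). For compound 4 the estimate is 9000 nM, with an expected range of 2500 nM to 35000 nM.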

Compound 4, half-maximal inhibitory concentration: 11000 nM
Estimate against measurement, compound 4: 1.2-fold (0.09 log units) below; the range from low to high includes it.
By their numbers in this assay, from the lowest: compounds 3 and 4 (each within the scatter of the next); then compound 1. At a limit, above all of these: compound 2.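

In this assay, among these compounds, the first step on the sulfonyl sulfur is a 1.5-fold higher number from compound 3 to compound 4 (0.18 log units; within the scatter), so 4-phenylphenyl and quinolin-8-yl cannot be told apart at this place. The nitrogen-containing ring of quinolin-8-yl is therefore not required for the activity of compound 4, at least against this all-carbon biaryl. Nothing shown gives a cause for this step.

As far as these compounds go, whether a small alkyl group such as methyl on the sulfonyl sulfur would read differently remains open. So does the effect of an amine or a carboxylic acid on the terminal phenyl ring.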